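Stretching an Ester Arm on a Shared Core

The source may hold more compounds than are shown below. What is called first, only, known or untested is meant among the compounds shown, and "the series" means these compounds.

Of the compounds shown here, three built on the same core have been tested in a functional assay on CLL cells (Homo sapiens) for cytotoxicity, read by MTT assay, with a stated time of 48 h; a higher number here means that more compound is needed for the effect, a lower number that less compound is needed. Compound 1 `C=C(CC)C(=O)c1ccc(OCC(=O)Nc2ccc(C(=O)OC)cc2)c(Cl)c1Cl` gives 4100 nM. Compound 2 `C=C(CC)C(=O)c1ccc(OCC(=O)Nc2ccc(O)c([N+](=O)[O-])c2)c(Cl)c1Cl` gives 7400 nM, and compound 3 `C=C(CC)C(=O)c1ccc(OCC(=O)Nc2ccc3nc[nH]c3c2)c(Cl)c1Cl` gives 3200 nM. Among these three numbers compound 1 stands second highest, but its nearest neighbour, compound 3, and its furthest neighbour, compound 2, both lie within the usual scatter of it, so the three values show no real separation from one another.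

The next compound to follow is compound 4 `C=C(CC)C(=O)c1ccc(OCC(=O)Nc2ccc(/C=C/C(=O)OCC)cc2)c(Cl)c1Cl`. It differs from compound 1 in one place: 2-(ethoxycarbonyl)ethenyl in place of methoxycarbonyl on an aromatic carbon. The methoxycarbonyl group leaves and a 2-(ethoxycarbonyl)ethenyl group enters on an aromatic carbon of a six-membered aromatic ring of carbon only, so the ester is carried out on a longer arm with one more double bond outside aromatic rings.

For the measured compounds named here, no measured pair among the three compounds shows what such a change does in this assay, so the expectation rests on compound 1 alone. The step from compound 1 to compound 4 is expected to stay within the scatter, a 1.2-fold lower number from compound 1 to compound 4 (0.07 log units; within the scatter), with no clear direction. Compound 4 is therefore estimated at 3500 nM, with a range from 1500 nM to 8000 nM.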

Compound 4, half-maximal effective concentration: 1700 nM
Compound 4: middle estimate off by 2.1-fold (0.31 log units), on the high side; low and high end bracket the measured number.
By their numbers in this assay, from the lowest: compounds 4, 3, 1 and 2 (each within the scatter of the next, the first and the last beyond it).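

In this assay, for the compounds shown here, replacing methoxycarbonyl with 2-(ethoxycarbonyl)ethenyl gives the only step in this set that can be read directly, and it lies beyond the scatter (a 2.4-fold lower number from compound 1 to compound 4 (0.38 log units; beyond the scatter)). This aromatic carbon, para to a large group, therefore accepts a substituent of 7 heavy atoms in place of one of 4, and less compound is needed for the effect, although the step is modest. No available evidence explains the fall, and this single step cannot separate the contributions of the longer arm, the added double bond and the ethyl ester in place of the methyl ester.

The compounds shown leave open whether the double bond itself matters, which a saturated chain carrying the same ethyl ester would test, and whether the ester matters, which a carboxylic acid or a primary amide at the end of the same arm would test. They also leave open whether the trend continues on a longer chain, so a single modest step cannot yet be called a pattern for this position.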